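A Chloropyridine Replaces the Pyrazole: Expected Binding of Compound 4

A few compounds are considered here, and "the series" means these few. Any claim that something is new, unique, unknown or untested is made for them only; others in the source may bear on it.

Three compounds were measured in an in vitro assay on HEK385-7 cells for displacement of a labelled ligand from prostaglandin D2 receptor 2 (Homo sapiens); a higher number here means a weaker inhibitor, a lower number a stronger inhibitor:
Compound 1, `O=C(O)Cc1sc(C(c2ccc(F)cc2)c2ccc(F)cc2)nc1-c1ccc(Cl)cc1`: 9.7 nM
Compound 2, `N#Cc1cc(-c2nc(C(c3ccc(F)cc3)c3ccc(F)cc3)sc2CC(=O)O)ccc1F`: 57 nM
Compound 3, `O=C(O)Cc1sc(C(c2ccc(F)cc2)c2ccc(F)cc2)nc1-c1cn[nH]c1`: 16 nM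

Compound 3 stands second highest of these three numbers; its nearest neighbour is compound 1, as a 1.6-fold higher number from compound 1 to compound 3 (0.22 log units; within the scatter) shows, and its furthest is compound 2, a 3.6-fold lower number from compound 2 to compound 3 (0.55 log units; beyond the scatter). Compound 4, `O=C(O)Cc1sc(C(c2ccc(F)cc2)c2ccc(F)cc2)nc1-c1ccnc(Cl)c1`, differs from compound 3 in one place: 2-chloropyridin-4-yl in place of 1H-pyrazol-4-yl on an aromatic carbon. Within the data shown here, the steps that bear on this change are a 1.6-fold higher number from compound 1 to compound 3 (0.22 log units; within the scatter), where a six-membered ring carrying chlorine already gave a similar number, and a 5.9-fold higher number from compound 1 to compound 2 (0.77 log units; beyond the scatter), where a differently substituted six-membered ring cost potency. A chlorine-bearing six-membered ring with one ring nitrogen is therefore expected to land close to compound 3. Compound 4 is estimated at 20 nM, with a range from 7 nM to 60 nM. The expected step of a 1.3-fold higher number from compound 3 to compound 4 (0.10 log units; within the scatter) lies within the scatter.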

Compound 4, half-maximal inhibitory concentration: 3.1 nM
Compound 4: middle estimate off by 6.5-fold (0.81 log units), on the high side, outside the stated range (below it).
By their numbers in this assay, from the lowest: compound 4; then compounds 1 and 3 (each within the scatter of the next); then compound 2.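

With the 2-chloropyridin-4-yl group, compound 4 has the lowest number at this position, and each comparison is beyond the scatter: a 5.2-fold lower number from compound 3 to compound 4 (0.71 log units; beyond the scatter), a 3.1-fold lower number from compound 1 to compound 4 (0.50 log units; beyond the scatter) and an 18-fold lower number from compound 2 to compound 4 (1.26 log units; beyond the scatter). Six-membered rings therefore fall on both sides of the 1H-pyrazol-4-yl group, so ring size alone does not set the number. A hydrogen-bond donor on this group is also not required for a low number.

No evidence available here explains the gain. A pyridin-4-yl group without chlorine, or a 2-methylpyridin-4-yl group, would help separate the contributions of the chlorine and the ring nitrogen.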